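Adding an Acetyl Group to Compound 2

The compounds below may be only part of what the source reports. "The series", "measured", "known", "first", "only" and "open" are said of these compounds alone.

Compound 1 `CCNC(=O)CCc1cccc2c1B(O)OC2`: > 100000 nM
Compound 2 `O=C(CCc1cccc2c1B(O)OC2)Nc1cccc(-c2ccccc2)c1`: 890 nM
Compound 3 `O=C(CCc1cccc2c1B(O)OC2)Nc1ccc(-c2ccccc2)cc1`: 13000 nM

Of the compounds shown here, three have so far been tested in a functional assay on HCT-116 cells (Homo sapiens) for antiproliferative activity, read by MTT assay, with a stated time of 72 h; on this read-out higher numbers stand for weaker inhibition and lower numbers for stronger inhibition. For compound 1 the result is only a limit of the assay, > 100000 nM. Compound 2 gives 890 nM, the lowest of the two numbers. Compound 3 gives 13000 nM, a gap from compound 2 that lies beyond the scatter. Compound 4 `CC(=O)c1cccc(-c2cccc(NC(=O)CCc3cccc4c3B(O)OC4)c2)c1` has not yet been measured; it differs from compound 2 by acetyl in place of hydrogen on an aromatic carbon. Within the data shown here, no measured pair shares this change, so the expected step in this assay is small, within the scatter, in either direction. The step expected is a 1.1-fold higher number from compound 2 to compound 4 (0.05 log units; within the scatter). Compound 4 is thus estimated at 1000 nM, with a range from 300 nM to 4000 nM.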

Compound 4, half-maximal inhibitory concentration: 86 nM
Compound 4: the middle estimate sits 12-fold (1.07 log units) above what was measured; measured number outside the range, below it.
By their numbers in this assay, from the lowest: compound 4; then compound 2; then compound 3. At a limit, above all of these: compound 1.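

Changing phenyl to 3-acetylphenyl is a large step in this assay, with stronger inhibition: a 10-fold lower number from compound 2 to compound 4 (1.01 log units; beyond the scatter). So this aromatic carbon, meta to a large group, can take a group of 3 heavy atoms, and the activity depends on what sits there. Nothing shown explains why the step is this large. The compounds shown leave open whether this step belongs to acetyl itself or would also come with a methyl, an amine or a carboxylic acid on the same carbon. They also leave open whether acetyl would give a similar step on compound 3.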